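This account rests on a few compounds, and the source may have more. Where it says the series, first, only, none or still open, it means among the compounds named here.

Measured so far in a functional assay on HepG2 cells (Homo sapiens) for inhibition, read by CCK-8 assay, with a stated time of 48 h; a lower number here means a stronger inhibitor, a higher number a weaker inhibitor:
- compound 1 `Fc1ccc(C2=NN(C3=NC(c4ccccc4)CS3)C(c3ccc4ccccc4c3)C2)cc1`: 26500 nM
- compound 2 `Cc1ccc(C2=NN(C3=NC(c4ccccc4)CS3)C(c3ccc4ccccc4c3)C2)cc1C`: 7370 nM

Going by the values given here, compound 2 stands lowest of the two numbers in this assay; the only neighbour is compound 1, and the step of a 3.6-fold lower number from compound 1 to compound 2 (0.56 log units; beyond the scatter) lies beyond the scatter.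

Compound 3 `Clc1ccc(C2=NN(C3=NC(c4ccccc4)CS3)C(c3ccc4ccccc4c3)C2)cc1` is not yet measured. It differs from compound 2 by 4-chlorophenyl in place of 3,4-dimethylphenyl on a carbon with a double bond to nitrogen. Among the compounds with values here, the one measured step that bears on this change is a 3.6-fold lower number from compound 1 to compound 2 (0.56 log units; beyond the scatter), where a 4-fluorophenyl gave way to the 3,4-dimethylphenyl. Within the data shown here, compound 3 partly undoes that change, returning to a singly halogen-bearing phenyl, now 4-chlorophenyl; no measured pair shows how chlorine and fluorine compare at that place. The number for compound 3 is therefore expected to rise relative to compound 2, by a step of a 2.0-fold higher number from compound 2 to compound 3 (0.31 log units; beyond the scatter), but probably by less than the full step seen from compound 1, so compound 3 is estimated at 15000 nM, within 5000 nM to 45000 nM.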

Compound 3, half-maximal inhibitory concentration: 22100 nM
The estimate for compound 3 lay 1.5-fold (0.17 log units) below the measured number; the measured number falls inside the stated range.
By their numbers in this assay, from the lowest: compound 2; then compounds 3 and 1 (each within the scatter of the next).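

On this carbon with a double bond to nitrogen, the 4-chlorophenyl of compound 3 gives a 3.0-fold higher number from compound 2 to compound 3 (0.48 log units; beyond the scatter) in this assay, so the 3,4-dimethylphenyl of compound 2 now stands apart from both halogen-bearing phenyl groups, with steps beyond the scatter on each side. The swap of fluoro for chloro on the aromatic carbon gives a 1.2-fold lower number from compound 1 to compound 3 (0.08 log units; within the scatter) and so separates neither halogen from the other, which makes compound 2 the strongest inhibitor of the three. Nothing measured on these compounds accounts for the difference between the 3,4-dimethylphenyl and the halogen-bearing phenyl groups.

Whether both methyl groups are needed remains open, since the compounds shown include no phenyl carrying a single methyl. Also open, going by these compounds, is how a methoxy group or an amine on this phenyl would compare, and whether the ring atom that bears a naphthalen-2-yl group tolerates another group there.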